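The source may report more compounds than this note shows. Statements on the series, on what has been measured and on what is new or still open speak of the compounds shown alone.

Measured so far:
compound 1, `N#CC1=C(N)OC(c2c[nH]c3ccccc23)=C(C#N)C1c1ccc(Br)cc1`: 947 ug/mL
compound 2, `Cc1ccccc1C1C(C#N)=C(N)OC(c2c[nH]c3ccccc23)=C1C#N`: > 1000 ug/mL

In a functional assay (on this read-out higher numbers stand for weaker inhibition and lower numbers for stronger inhibition), compound 1 gives 947 ug/mL. For compound 2 the recorded value > 1000 ug/mL is a limit of this assay and not a number, because compound 2 sits at the limit of > 1000 ug/mL in this assay, at which 1 of the 2 values shown sits. Compound 2 therefore stands only on a limit, and the step of an at least 1.0-fold higher number from compound 1 to compound 2 (0.02 log units; that floor lies within the scatter) lies within the scatter of repeated measurements, so the two compounds cannot be ordered against each other.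

Compound 3, `N#CC1=C(N)OC(c2c[nH]c3ccccc23)=C(C#N)C1c1ccccc1`, has not been measured. It differs from compound 2 by hydrogen in place of methyl on an aromatic carbon; cut one bond further out, the change reads 2-methylphenyl to phenyl. Within the data shown here, the only measured step that bears on this change is the swap of the aryl group on the saturated ring carbon, an at least 1.0-fold higher number from compound 1 to compound 2 (0.02 log units; that floor lies within the scatter), which did not move the read-out beyond the scatter. The step from compound 2 to compound 3 is a smaller alteration of the same aryl group, so no step beyond the scatter is expected: a number no higher from compound 2 to compound 3 (the limit leaves the size open).

Compound 3 is estimated at 1000 ug/mL in this assay, with a range of 600 ug/mL to 1700 ug/mL, and it may well again be reported only as a limit.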

Compound 3, half-maximal inhibitory concentration: 994 ug/mL
Estimate against measurement, compound 3: 1.0-fold (0.00 log units) above; measured number inside the range.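

In this assay compound 3, which carries an unsubstituted phenyl on the saturated ring carbon, gives 994 ug/mL. Among these compounds, this supplies the first readable comparison of a single substituent on this aryl group: hydrogen in place of bromo gives a 1.0-fold higher number from compound 1 to compound 3 (0.02 log units; within the scatter), so this read-out does not tell the two apart at this place. Hydrogen in place of methyl on an aromatic carbon gives a number no higher from compound 2 to compound 3 (the limit leaves the size open). The value of compound 2, > 1000 ug/mL, is a limit and not a number, and the steps from compound 2 cannot be read for that reason: the limit of > 1000 ug/mL in this assay, at which 1 of the 3 values shown sits.

The compounds shown leave open whether an amine, a hydroxyl or a carboxylic acid on this aryl group would move the read-out beyond the scatter. They also leave open whether a change in the shared core, such as an amide in place of a nitrile, would do so, as all three compounds carry that core unchanged.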